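A few compounds are considered here, and "the series" means these few. Any claim that something is new, unique, unknown or untested is made for them only; others in the source may bear on it.

Compound 1 `CN1CCc2nc(C#Cc3cccc(F)c3)sc2C1`: > 10000 nM
Compound 2 `C(#Cc1nc2c(s1)CN(C1CCCCC1)CC2)c1ccccc1`: > 10000 nM

In an assay on HEK293 cells for negative allosteric modulation of metabotropic glutamate receptor 5 (Homo sapiens), read by FLIPR, with a stated time of 1 h (on this read-out lower numbers stand for stronger inhibition and higher numbers for weaker inhibition), compound 2 reaches only a limit, > 10000 nM. Compound 1 likewise gives a limit, > 10000 nM. Both shown values therefore sit at the limit of > 10000 nM in this assay, at which 2 of the 2 values shown sit, and compound 2 has no number of its own to stand above or below. Compound 3 `O=C(C1CC12CCC2)N1CCc2nc(C#Cc3ccccc3)sc2C1` carries a group of 8 heavy atoms (7 carbon, 1 oxygen; one three-membered non-aromatic ring of carbon only, one four-membered non-aromatic ring of carbon only) in place of a group of 6 heavy atoms (6 carbon; one six-membered non-aromatic ring of carbon only), on an amine nitrogen in a ring. For the measured compounds named here, no measured pair shares this change, so the expected step in this assay rests on the limit of compound 2 alone. A move past that limit toward stronger inhibition is expected, an at least 33-fold lower number from compound 2 to compound 3 (1.52 log units; beyond the scatter). Compound 3 is estimated at 300 nM, within 30 nM to 10000 nM.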

Compound 3, half-maximal inhibitory concentration: > 10000 nM
Compound 3 was reported as a limit; the forecaster's own chance of this, stated with the estimate: 25%; at least 33-fold (1.52 log units) between middle value and limit.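

In this assay, for the compounds shown here, compound 3 gives only a limit, > 10000 nM, so no step from compound 2 to compound 3 can be read. The compounds shown leave open how any group on the amine nitrogen in a ring changes inhibition, with every value at one limit: the limit of > 10000 nM in this assay, at which 3 of the 3 values shown sit.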